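A Furan Ring Takes the Place of the Benzoyl Phenyl

This account rests on a few compounds, and the source may have more. Where it says the series, first, only, none or still open, it means among the compounds named here.

Compound 1 `CC1(C)S[C@@H]2/C(=C\C(=O)c3ccccc3)C(=O)N2[C@H]1C(=O)OC(c1ccccc1)c1ccccc1` was examined in a functional assay on HT-1080 cells (Homo sapiens) for cytotoxicity, read by MTT assay, with a stated time of 48 h (on this read-out lower numbers stand for stronger inhibition and higher numbers for weaker inhibition), where compound 1 gives 21100 nM. Two companions were measured alongside it. Compound 2 `CC1(C)[C@H](C(=O)OC(c2ccccc2)c2ccccc2)N2C(=O)/C(=C/C(=O)c3ccccc3)[C@H]2S1(=O)=O` gives 19500 nM in this assay, a number that sits within the scatter of compound 1, so the two cannot be ranked against each other. Compound 3 `CC1(C)[C@H](C(=O)OC(c2ccccc2)c2ccccc2)N2C(=O)/C(=C/C(=O)c3ccccc3)[C@H]2[S+]1[O-]` gives 65500 nM in this assay, a gap to compound 1 that lies beyond the scatter. On these three numbers compound 1 therefore stands second highest, separated only from compound 3.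

The next compound, compound 4 `CC1(C)S[C@@H]2/C(=C\C(=O)c3ccco3)C(=O)N2[C@H]1C(=O)OC(c1ccccc1)c1ccccc1`, differs from compound 1 by furan-2-yl in place of phenyl on a carbonyl carbon. Among the compounds with values here, no measured pair among the three compounds shows this change, so the expectation rests on compound 1 alone. The step from compound 1 to compound 4 is expected to be small, as a 1.2-fold higher number from compound 1 to compound 4 (0.09 log units; within the scatter), leaning toward a slightly higher number but not beyond the scatter. Compound 4 is thus estimated at 26000 nM, with a range from 10000 nM to 65000 nM.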

Compound 4, half-maximal inhibitory concentration: 45500 nM
Compound 4: the middle estimate sits 1.8-fold (0.24 log units) below what was measured; the range from low to high includes it.
By their numbers in this assay, from the lowest: compounds 2 and 1 (each within the scatter of the next); then compounds 4 and 3 (each within the scatter of the next).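

In this assay the exchange of phenyl for furan-2-yl on a carbonyl carbon gives a 2.2-fold higher number from compound 1 to compound 4 (0.33 log units; beyond the scatter) and so lies beyond the scatter, which shows that this position responds to a change of the aromatic ring, if only modestly. Compounds 1, 2 and 3 all carry the benzoyl group, so they could not show this. Nothing measured here gives a reason for the step.

Going by these compounds, what remains open is whether the step follows the ring oxygen or the smaller ring, a question that a thiophen-2-yl or a pyridine ring on the same carbonyl carbon would address. Also open, on these data alone, is whether a non-aromatic group such as cyclohexyl or methyl would be tolerated there, and whether the same exchange would give a similar step in the compounds with oxidised sulfur, compound 2 and compound 3.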